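The source may hold more compounds than are shown below. What is called first, only, known or untested is meant among the compounds shown, and "the series" means these compounds.

Compound 1 `COc1cc2c(Nc3ccc(C#N)cc3)ncnc2cc1OCCCN(C)C`: 35300 nM
Compound 2 `COc1cc2c(Nc3ccc(C#N)cc3)ncnc2cc1OCCCN1CCC(C)CC1`: 16600 nM
Compound 3 `CCOC(=O)C1CCN(CCCOc2cc3ncnc(Nc4ccc(C#N)cc4)c3cc2OC)CC1`: 52300 nM

These numbers come from a functional assay on DU-145 cells (Homo sapiens) for antiproliferative activity, read by MTT assay, with a stated time of 72 h; a lower number here means a stronger inhibitor, a higher number a weaker inhibitor. Compound 3 gives the highest number of the three; its gap to compound 1 is within the scatter, while the step of a 3.2-fold higher number from compound 2 to compound 3 (0.50 log units; beyond the scatter) lies beyond it. Compound 4 `COc1cc2c(Nc3ccc(C#N)cc3)ncnc2cc1OCCCN1CCc2ccccc2C1` carries 1,2,3,4-tetrahydroisoquinolin-2-yl in place of 4-(ethoxycarbonyl)piperidin-1-yl on a saturated chain carbon, three bonds along the chain from an oxygen on an aromatic ring. Among the measured compounds shown here, two measured steps bear on this: a 3.2-fold higher number from compound 2 to compound 3 (0.50 log units; beyond the scatter) showed that putting ethoxycarbonyl on the ring in place of methyl raised the number modestly, and a 1.5-fold higher number from compound 1 to compound 3 (0.17 log units; within the scatter) stayed within the scatter. Compound 4 removes the ethoxycarbonyl and keeps a six-membered ring with one nitrogen, closest in build to compound 2, so a modestly lower number in this assay is expected, roughly back to the level of compound 2. Compound 4 is estimated at 16000 nM (range 5000 nM to 45000 nM), which means a step of a 3.3-fold lower number from compound 3 to compound 4 (0.51 log units; beyond the scatter).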

Compound 4, half-maximal inhibitory concentration: > 100000 nM
Compound 4 was reported as a limit (the forecaster's own chance of this, stated with the estimate: 5%); at least 6.2-fold (0.79 log units) between middle value and limit.
By their numbers in this assay, from the lowest: compound 2; then compounds 1 and 3 (each within the scatter of the next). At a limit, above all of these: compound 4.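

In this assay, compound 4 is reported only as a limit: the limit of > 100000 nM in this assay, at which 1 of the 4 values shown sits.

At this place, on a saturated chain carbon, three bonds along the chain from an oxygen on an aromatic ring, 1,2,3,4-tetrahydroisoquinolin-2-yl gives a loss beyond the scatter in an at least 6.0-fold higher number from compound 2 to compound 4 (0.77 log units; beyond the scatter) and in an at least 2.8-fold higher number from compound 1 to compound 4 (0.45 log units; beyond the scatter), while the floor in an at least 1.9-fold higher number from compound 3 to compound 4 (0.28 log units; that floor lies within the scatter) settles no order. Ring amines are therefore not interchangeable here: the piperidin-1-yl groups of compound 2 and compound 3 give measured values, the new group only a limit.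

Whether the aromatic ring alone accounts for this stays open. A morpholin-4-yl or pyrrolidin-1-yl group, or a longer chain, could still fall on either side of compound 2.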